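The source may hold more compounds than are shown below. What is called first, only, known or untested is meant among the compounds shown, and "the series" means these compounds.

Measured compounds:

- compound 1 `Nc1sc(-c2ccc(Cl)cc2)c(-c2ccc(Cl)cc2)c1C(=O)NC1CCC(O)CC1` gives 5670 nM in a functional assay on PC-3 cells (Homo sapiens) for inhibition, read by sulforhodamine B assay, with a stated time of 72 h; on this read-out lower numbers stand for stronger inhibition and higher numbers for weaker inhibition
- compound 2 `CC(C)CNC(=O)c1c(N)sc(-c2ccc(Cl)cc2)c1-c1ccc(Cl)cc1` gives 13200 nM
- compound 3 `CC(=O)Nc1sc(-c2ccc(Cl)cc2)c(-c2ccc(Cl)cc2)c1C(=O)N1CCCCC1` gives 10300 nM

Among these three numbers compound 1 has the lowest, that is, the strongest inhibition recorded so far. Compound 3 sits closest to it, a gap that falls within the usual scatter, so the two cannot be ranked against each other; compound 2 lies furthest away, a gap that goes beyond the scatter.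

Compound 4 `Nc1sc(-c2ccc(Cl)cc2)c(-c2ccc(Cl)cc2)c1C(=O)NC1CC1` has not yet been measured. It differs from compound 1 in one place: cyclopropyl in place of 4-hydroxycyclohexyl on an amide-type nitrogen.

For the measured compounds named here, one measured step bears on this change, because it too alters the group on the amide-type nitrogen of the same core: a 2.3-fold higher number from compound 1 to compound 2 (0.37 log units; beyond the scatter). That step swapped the 4-hydroxycyclohexyl for isobutyl and weakened inhibition modestly. The move to cyclopropyl is a smaller group again and, like isobutyl, brings no hydrogen-bond donor or acceptor, so a step of similar size in the same direction is the most reasonable expectation in this assay, with a real chance that it stays within the scatter.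

Compound 4 is therefore estimated at 9500 nM, with a range from 4000 nM to 22000 nM, which would mean an expected 1.7-fold higher number from compound 1 to compound 4 (0.22 log units; within the scatter).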

Compound 4, half-maximal inhibitory concentration: 3680 nM
Estimate against measurement, compound 4: 2.6-fold (0.41 log units) above; measured number below the stated range.
By their numbers in this assay, from the lowest: compounds 4, 1, 3 and 2 (each within the scatter of the next, the first and the last beyond it).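

In this assay, cyclopropyl in place of 4-hydroxycyclohexyl on the amide-type nitrogen gives a 1.5-fold lower number from compound 1 to compound 4 (0.19 log units; within the scatter), so this change leaves no readable difference, even though a group of 7 heavy atoms with 1 hydrogen-bond donor and 1 hydrogen-bond acceptor gives way to one of 3 heavy atoms with neither. The group on this nitrogen can still shift the number: cyclopropyl in place of isobutyl gives a 3.6-fold lower number from compound 2 to compound 4 (0.55 log units; beyond the scatter). Compound 4 has no hydroxyl group on this nitrogen's substituent, and its number lies within the scatter of that of compound 1. Nothing available here explains why isobutyl and cyclopropyl differ on this nitrogen.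

On these data alone, it remains open how a plain cyclohexyl, with no hydroxyl group, would compare with 4-hydroxycyclohexyl, and whether cyclobutyl would track cyclopropyl or isobutyl. A longer chain or a chain ending in an amine or a carboxylic acid on this nitrogen would also test how far this position tolerates change.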